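The source may hold more compounds than are shown below. What is called first, only, known or untested is meant among the compounds shown, and "the series" means these compounds.

Working notes on the series, read in a functional assay on HeLa cells (Homo sapiens) for antiproliferative activity, read by MTT assay, with a stated time of 48 h; a higher number here means a weaker inhibitor, a lower number a stronger inhibitor: compound 1 `COc1ccc(C(=O)c2ccc(OC)c3c2C=CC(C)(C)O3)c(NC(=O)CN(C)C)c1` gives 3620 nM, compound 2 `C=C(c1ccc(OC)cc1NC(=O)CN)c1ccc(OC)c2c1OC(C)(C)C=C2` gives 120 nM and compound 3 `C=C(c1ccc(OC)cc1NC(=O)CNC)c1ccc(OC)c2c1OC(C)(C)C=C2` gives 310 nM, the second highest of the three numbers. Compound 4 `C=C(c1ccc(OC)cc1NC(=O)CN(C)C)c1ccc(OC)c2c1OC(C)(C)C=C2` differs from compound 3 by methyl in place of hydrogen on an amine nitrogen, methylamino becoming dimethylamino: methyl in place of hydrogen on an amine nitrogen. Going by the values given here, the only measured step of this kind, a 2.6-fold higher number from compound 2 to compound 3 (0.41 log units; beyond the scatter), is modest and beyond the scatter, and it is a single precedent. A step of similar size towards a higher number is therefore expected, and the estimated step is a 2.4-fold higher number from compound 3 to compound 4 (0.38 log units; beyond the scatter). For compound 4 the estimate is 750 nM, with an expected range of 280 nM to 2000 nM.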

Compound 4, half-maximal inhibitory concentration: 900 nM
Estimate against measurement, compound 4: 1.2-fold (0.08 log units) below, within the range that was stated.
By their numbers in this assay, from the lowest: compound 2; then compound 3; then compound 4; then compound 1.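

In this assay a second methyl on this amine nitrogen gives a 2.9-fold higher number from compound 3 to compound 4 (0.46 log units; beyond the scatter) and so moves the number the same way as the first methyl, which gave a 2.6-fold higher number from compound 2 to compound 3 (0.41 log units; beyond the scatter) in a step also called modest. Over the whole change, dimethylamino in place of amino gives a 7.5-fold higher number from compound 2 to compound 4 (0.88 log units; beyond the scatter) and the number rises with each added methyl across these three compounds, with none going against it. No measurement at hand bears on the reason for this rise.

Going by these compounds, whether an ethyl or a larger group on this nitrogen extends the rise remains open. So does the effect of a hydroxyl in place of the amine.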